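The source may report more compounds than this note shows. Statements on the series, on what has been measured and on what is new or still open speak of the compounds shown alone.

Compound 1, with structure `Cc1cccc(/C(N)=N/NC(=S)N2CCSCC2)n1`, and compound 2, with structure `Cc1cccc(/C(N)=N/NC(=S)N2CCOCC2)n1`, differ at a single point: morpholin-4-yl in place of thiomorpholin-4-yl on a thiocarbonyl carbon. Compound 3, with structure `N/C(=N\NC(=S)N1CCSCC1)c1ccc(F)cn1`, carries the same thiomorpholin-4-yl group as compound 1 but sits on a different core; how the two cores differ is not broken down here. Compound 4, with structure `N/C(=N\NC(=S)N1CCOCC1)c1ccc(F)cn1`, has not yet been measured. It stands to compound 3 exactly as compound 2 stands to compound 1, the change being (morpholin-4-yl in place of thiomorpholin-4-yl on a thiocarbonyl carbon), made at the same place, so this is the same change rather than merely a related one.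

In a functional assay on A-431 cells (Homo sapiens) for cytotoxicity, read by MTT assay, with a stated time of 72 h (a lower number here means a stronger inhibitor, a higher number a weaker inhibitor), compound 1 gives 2600 nM, and compound 2 gives 4300 nM. Swapping the one group for the other made a 1.7-fold higher number from compound 1 to compound 2 (0.22 log units; within the scatter), a step small enough that it cannot be told apart from ordinary repeat measurements. Compound 3 gives 1200 nM in this assay, the lowest of the three numbers and beyond the scatter from both of the others.

The same swap is now applied to compound 3. Because the swap earlier produced a 1.7-fold higher number from compound 1 to compound 2 (0.22 log units; within the scatter), a similarly small step is expected for compound 4, a 1.7-fold higher number from compound 3 to compound 4 (0.22 log units; within the scatter). That expectation rests on one measured pair only, so the range is kept wide. The estimate for compound 4 in this assay is 2000 nM, expected to fall between 1000 nM and 4500 nM.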

Compound 4, half-maximal inhibitory concentration: 4000 nM
For compound 4 the middle estimate is 2.0-fold (0.30 log units) below the measured one, within the range that was stated.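

In this assay, the same swap gave a 3.3-fold higher number from compound 3 to compound 4 (0.52 log units; beyond the scatter), and this step, unlike the earlier one, stands clear of ordinary repeat variation. Even so, the two steps cannot be told apart when set side by side: the same change on two cores in this assay, a 1.7-fold higher number (0.22 log units; within the scatter) from compound 1 to compound 2 and a 3.3-fold higher number (0.52 log units; beyond the scatter) from compound 3 to compound 4, 2.0-fold (0.30 log units) apart, within the scatter of two such steps The simplest reading is therefore that the change carries over between these two cores with a step of similar size, but this rests on only two matched pairs, and it does not show that the steps are truly equal, that the same would hold on a third core, or why the swap acts as it does.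

The compounds shown leave open how other groups on the thiocarbonyl carbon would read in this assay, such as piperidin-1-yl, piperazin-1-yl or an open-chain dimethylamino group, all of which would show whether the sulfur and oxygen of these two rings are the only features that matter. They also leave open whether the same swap gives a similar step on cores beyond those of compound 1 and compound 3.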